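Swapping 6-Fluoropyridin-3-yl for Phenyl in Compound 1

The compounds below may be only part of what the source reports. "The series", "measured", "known", "first", "only" and "open" are said of these compounds alone.

compound 1 `COc1ccc(S(=O)(=O)N2CCc3cccc(-c4ccc(F)nc4)c32)cc1` — 109 nM
compound 2 `COc1ccc(S(=O)(=O)N2CCc3cccc(-c4c(F)c(F)c(F)c(F)c4F)c32)cc1` — 3900 nM
compound 3 `COc1ccc(S(=O)(=O)N2CCc3cccc(-c4cc(OC)c(OC)c(OC)c4)c32)cc1` — 5100 nM

Of the compounds shown here, three sharing one core have been measured in a functional assay on HT-29 cells (Homo sapiens) for inhibition, with a stated time of 72 h; on this read-out lower numbers stand for stronger inhibition and higher numbers for weaker inhibition. Compound 1 stands lowest of the three, and both compound 2 and compound 3 lie well above it, each beyond the usual scatter. Compound 4 `COc1ccc(S(=O)(=O)N2CCc3cccc(-c4ccccc4)c32)cc1` is not yet measured. It differs from compound 1 in one place: phenyl in place of 6-fluoropyridin-3-yl on an aromatic carbon. Among the measured compounds shown here, no pair of measured compounds differing in a single place is available, so the size of this step rests on expectation alone. Compound 4 is expected to weaken somewhat, with a step of a 2.8-fold higher number from compound 1 to compound 4 (0.44 log units; beyond the scatter) that is modest but likely beyond the scatter. Compound 4 is estimated at 300 nM, within a range from 100 nM to 1200 nM.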

Compound 4, half-maximal inhibitory concentration: 96.5 nM
Compound 4: middle estimate off by 3.1-fold (0.49 log units), on the high side; measured number below the stated range.
By their numbers in this assay, from the lowest: compounds 4 and 1 (each within the scatter of the next); then compounds 2 and 3 (each within the scatter of the next).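

In this assay, the first pair differing in a single place shows a 1.1-fold lower number from compound 1 to compound 4 (0.05 log units; within the scatter) for phenyl in place of 6-fluoropyridin-3-yl on this aromatic carbon. The two groups therefore cannot be told apart on this read-out, and neither the ring nitrogen nor the fluorine of 6-fluoropyridin-3-yl is needed for a number at this level. Nothing available explains why the two rings read alike.

Still open, from the compounds shown here alone, is whether a single methoxy group or a single fluorine on the phenyl of compound 4 would hold this level. Also open, going by these compounds, is whether a non-aromatic group on this carbon, such as morpholine or a carboxylic acid, would hold it.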